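Swapping pyridin-3-yl for (phenylsulfanyl)methyl on a carbonyl carbon

The source may report more compounds than this note shows. Statements on the series, on what has been measured and on what is new or still open speak of the compounds shown alone.

In a functional assay (aorta) with Rattus norvegicus as the target (on this read-out lower numbers stand for an effect already at smaller amounts and higher numbers for an effect only at larger amounts of compound), compound 1 `COc1ccc(-c2nc(CNC(C)=O)sc2-c2ccc(OC)cc2)cc1` gives 8.1 uM. Compound 2 `COc1ccc(-c2nc(CNC(=O)c3cccnc3)sc2-c2ccc(OC)cc2)cc1` gives 8.2 uM, which leaves it level with compound 1 within the scatter. The next compound, compound 3 `COc1ccc(-c2nc(CNC(=O)CSc3ccccc3)sc2-c2ccc(OC)cc2)cc1`, differs from compound 2 by one group: (phenylsulfanyl)methyl in place of pyridin-3-yl on a carbonyl carbon. Put in words, (phenylsulfanyl)methyl stands in place of pyridin-3-yl on a carbonyl carbon whose other neighbour is an amide-type nitrogen. Among the compounds with values here, only one measured step bears on this change, a 1.0-fold higher number from compound 1 to compound 2 (0.01 log units; within the scatter), which exchanged the group on that same carbonyl carbon and stayed within the scatter. A single step is thin evidence, and the new group has not yet been tested, but no step beyond the scatter is expected in this assay. The expected change is a 1.2-fold lower number from compound 2 to compound 3 (0.07 log units; within the scatter). Compound 3 is estimated at 7 uM, with an expected range from 2.5 uM to 20 uM.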

Compound 3, concentration for half-maximal effect: 4.2 uM
Estimate against measurement, compound 3: 1.7-fold (0.22 log units) above; the range from low to high includes it.
By their numbers in this assay, from the lowest: compounds 3, 1 and 2 (each within the scatter of the next).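

In this assay, the exchange on the carbonyl carbon gives a 2.0-fold lower number from compound 2 to compound 3 (0.29 log units; within the scatter) and remains level, while adding phenylsulfanyl in place of hydrogen on the saturated chain carbon bound to that carbonyl carbon gives a 1.9-fold lower number from compound 1 to compound 3 (0.29 log units; within the scatter) and also stays level. Within the data shown here, this position has therefore now carried methyl, pyridin-3-yl and (phenylsulfanyl)methyl, and no step among compounds 1, 2 and 3 lies beyond the scatter, even with the group that brings a sulfur and a carbon-only ring. Nothing measured here offers an explanation for these numbers.

As far as these compounds go, whether an amine, a carboxylic acid or a longer chain on this carbonyl carbon would produce a step beyond the scatter remains open. Also open, from the compounds shown here alone, is whether the sulfur of (phenylsulfanyl)methyl counts on its own.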